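Replacing a Non-Aromatic Ring with an Aromatic One

This account rests on a few compounds, and the source may have more. Where it says the series, first, only, none or still open, it means among the compounds named here.

Three compounds sharing one core have numbers in an ADME assay (liver, Mus musculus) for metabolic stability, using microsomes; a higher number here means that the compound lasts longer, a lower number that the compound disappears faster. Compound 1 `CCc1nc2cc(Cl)ccn2c1C(=O)NCc1ccc(-c2ccc(C)cc2)cc1` gives 0.385 h, compound 2 `CCc1nc2cc(Cl)ccn2c1C(=O)NCc1ccc(N2CCCCC2)cc1` gives 0.0383 h, and compound 3 `CCc1nc2cc(Cl)ccn2c1C(=O)NCc1ccc(N2CC3CCCCC3C2)cc1` gives 0.105 h, which makes compound 3 the second highest of the three.

Compound 4 `CCc1nc2cc(Cl)ccn2c1C(=O)NCc1ccc(-n2cc3c(c2)CCCC3)cc1` differs from compound 3 in a single group: a group of 9 heavy atoms (8 carbon, 1 nitrogen; one five-membered aromatic ring with 1 hetero atom, one six-membered non-aromatic ring of carbon only) in place of a group of 9 heavy atoms (8 carbon, 1 nitrogen; one five-membered non-aromatic ring with 1 hetero atom, one six-membered non-aromatic ring of carbon only), on an aromatic carbon. The five-membered non-aromatic ring with 1 hetero atom becomes a five-membered aromatic ring with 1 hetero atom, while the six-membered non-aromatic ring of carbon only remains.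

Among the compounds with values here, no measured step makes this exact change. The closest evidence concerns the loss of an aromatic ring at this place. Piperidin-1-yl in place of 4-methylphenyl gave a 10-fold lower number from compound 1 to compound 2 (1.00 log units; beyond the scatter), and the group with two non-aromatic rings gave a 3.7-fold lower number from compound 1 to compound 3 (0.56 log units; beyond the scatter). Between the two non-aromatic groups, the data show a 2.7-fold higher number from compound 2 to compound 3 (0.44 log units; beyond the scatter). Among these three compounds, the aromatic group goes with the highest number and no compound goes against that, but none carries the five-membered aromatic ring, so the guidance is weak.

The expected step is a 1.6-fold higher number from compound 3 to compound 4 (0.21 log units; within the scatter) in this assay, a small upward one. For compound 4 the estimated half-life is 0.17 h, with an expected range from 0.06 h to 0.45 h.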

Compound 4, half-life: 1.04 h
For compound 4 the middle estimate is 6.1-fold (0.79 log units) below the measured one, outside the stated range (above it).
By their numbers in this assay, from the lowest: compound 2; then compound 3; then compound 1; then compound 4.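

In this assay, turning the five-membered non-aromatic ring into a five-membered aromatic ring, while the six-membered non-aromatic ring of carbon only remains, gives a 9.9-fold higher number from compound 3 to compound 4 (1.00 log units; beyond the scatter), so at this place, on an aromatic carbon and para to a large group, the aromatic character of that one ring goes with a large change in the number. The same group gives a 27-fold higher number from compound 2 to compound 4 (1.43 log units; beyond the scatter) when it replaces piperidin-1-yl and a 2.7-fold higher number from compound 1 to compound 4 (0.43 log units; beyond the scatter) when it replaces 4-methylphenyl, which puts compound 4 at the top of the four, with its steps to all three others beyond the scatter. Compound 1 and compound 4, the two with an aromatic ring in this group, both stand above compound 2 and compound 3, and no compound shown goes against that, so a six-membered aromatic ring of carbon only is not required for the higher numbers.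

The compounds shown leave open whether a plain pyrrol-1-yl group, without the six-membered ring, would keep this gain, and whether an amine or a carboxylic acid on the five-membered aromatic ring would keep it. Nothing measured here speaks to the reason for these steps.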